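Swapping the halogenated phenyl ring on a shared scaffold

This account rests on a few compounds, and the source may have more. Where it says the series, first, only, none or still open, it means among the compounds named here.

Among the compounds with values here, compound 3, with the structure `CCn1ccc2cccc(C(c3cccc(Cl)c3)n3ccnc3)c21`, is one of three compounds measured in an assay for inhibition of Aromatase (Homo sapiens), using microsomes; a higher number here means a weaker inhibitor, a lower number a stronger inhibitor. In that assay compound 3 gives 170 nM. Its closest neighbour is compound 1, built as `CCN1CCc2cccc(C(c3cccc(Cl)c3)n3ccnc3)c21`, which in this assay gives 110 nM; the two numbers sit within the usual scatter of each other. Far away stands compound 2, built as `CCN1CCc2cccc(C(c3ccc(F)cc3)n3cncn3)c21`, which in this assay gives 2900 nM, a gap that lies well beyond the scatter. Compound 2 differs from compound 3 in more than one place, so no single change can be read from that gap.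

The next compound, compound 4, has the structure `CCn1ccc2cccc(C(c3ccc(Br)cc3)n3ccnc3)c21`. It differs from compound 3 in one place: 4-bromophenyl in place of 3-chlorophenyl on a saturated chain carbon bound to an aromatic carbon and an aromatic nitrogen. Within the data shown here, no measured pair shows this change on its own, and the three numbers give no guide to it. A step no larger than the scatter in this assay is expected, and the expected step from compound 3 to compound 4 is a 1.2-fold higher number from compound 3 to compound 4 (0.07 log units; within the scatter). Compound 4 is therefore estimated at 200 nM, within a range from 70 nM to 600 nM.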

Compound 4, half-maximal inhibitory concentration: 70 nM
Estimate against measurement, compound 4: 2.9-fold (0.46 log units) above, within the range that was stated.
By their numbers in this assay, from the lowest: compounds 4, 1 and 3 (each within the scatter of the next, the first and the last beyond it); then compound 2.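

At the saturated chain carbon bound to an aromatic carbon and an aromatic nitrogen, the choice of halogenated phenyl ring does register in this assay: moving to 4-bromophenyl gives a 2.4-fold lower number from compound 3 to compound 4 (0.39 log units; beyond the scatter) and so a modest step towards a stronger inhibitor, one that lies beyond the scatter. This is the only pair shown that differs in one place, and that one swap alters both the halogen and its printed ring position, so the step belongs to the pair of changes taken together. No measurement shown explains the step.

On these data alone, whether the halogen or its ring position matters more stays open, and 4-chlorophenyl or 3-bromophenyl at the same carbon would separate the two. Also open, as far as these compounds go, are how a plain phenyl or 4-methoxyphenyl ring would fare there, and whether the step holds on the core of compound 1.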